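The source may report more compounds than this note shows. Statements on the series, on what has been measured and on what is new or still open speak of the compounds shown alone.

Compound 1 `COc1ccc(OC/C(=N\NC(N)=S)c2ccc(Br)cc2)cc1`: 102000 nM
Compound 2 `CC(=O)Nc1ccc(OC/C(=N\NC(N)=S)c2ccc(Br)cc2)cc1`: 94900 nM

In an ADME assay on L929 cells (Mus musculus) for cytotoxicity, read by resazurin assay, with a stated time of 96 h (on this read-out lower numbers stand for higher toxicity in this test and higher numbers for lower toxicity in this test), compound 2 gives 94900 nM, and compound 1 gives 102000 nM. These two numbers lie within the scatter of each other, so compound 2 does not stand apart from compound 1.

The next compound is compound 3 `NC(=S)N/N=C(\COc1ccc(Cl)cc1)c1ccc(Br)cc1`, which carries chloro in place of acetamido on an aromatic carbon, para to a large group: chloro in place of acetamido on an aromatic carbon.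

Among the measured compounds shown here, the only measured step that bears on this change is a 1.1-fold lower number from compound 1 to compound 2 (0.03 log units; within the scatter), with acetamido in place of methoxy on an aromatic carbon. That is a single swap at this place, and chloro itself has not been measured here, so the guidance is thin. No change beyond the scatter is expected, and the estimated move is a 1.3-fold lower number from compound 2 to compound 3 (0.10 log units; within the scatter).

For compound 3 the estimated value is 75000 nM, with an expected range of 35000 nM to 140000 nM.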

Compound 3, half-maximal cytotoxic concentration: < 25100 nM
Compound 3 gave a limit, no number; the forecaster's own chance of this, stated with the estimate: 10%; at least 2.9-fold (0.47 log units) between middle value and limit.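

Up to this point, the only swap at this place on the aromatic ring, acetamido for methoxy, stayed within the scatter, so the position could have seemed indifferent to which group it carries. Chloro changes that picture in this assay: the result is an at least 3.7-fold lower number from compound 2 to compound 3 (0.57 log units; beyond the scatter), and likewise an at least 4.0-fold lower number from compound 1 to compound 3 (0.60 log units; beyond the scatter), so the group at this place can raise toxicity in this test. Compound 3 gave a limit and not a number, so the full size of both steps remains open: the limit of < 25100 nM in this assay, at which 1 of the 3 values shown sits.

A fluoro, a bromo, a methyl or an amine at this place would help show whether the shift belongs to chloro alone or extends to other groups. The compounds shown do not explain why chloro behaves differently from methoxy and acetamido.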